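The source may report more compounds than this note shows. Statements on the series, on what has been measured and on what is new or still open speak of the compounds shown alone.

Compound 1 `COc1cc(-c2cc(/C=C/C(=O)c3ccc(N)cc3)[nH]n2)cc(OC)c1OC` and compound 2 `COc1ccc(-c2cc(/C=C/C(=O)c3ccc(N)cc3)[nH]n2)cc1OC` share one core and differ only in that a hydrogen stands in place of a methoxy on an aromatic carbon. In a functional assay on Hs-578T cells (Homo sapiens) for cytotoxicity, read by sulforhodamine B assay, with a stated time of 48 h, tested at 1 uM (a higher number here means a weaker effect of the compound at the concentration tested, a lower number a stronger effect), compound 1 gives 87%, while compound 2 gives 96%; the step of a number 9 percentage points higher from compound 1 to compound 2 (within the scatter) is within the scatter, so the two numbers cannot be told apart, and both describe a weak effect at the concentration tested.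

Compound 3 `COc1cc(-c2cc(/C=C/C(=O)c3ccc(F)c(F)c3)[nH]n2)cc(OC)c1OC` has not yet been measured. It differs from compound 1 in a single place, (3,4-difluorophenyl in place of 4-aminophenyl on a carbonyl carbon), that is, on the carbonyl carbon whose other neighbour is a double-bonded chain carbon. Within the data shown here, no measured step touches this part of the molecule: the only step available, from compound 1 to compound 2, concerns a methoxy on the other aromatic ring and was itself within the scatter. There is therefore no basis in these numbers for expecting a step beyond the scatter in this assay, though the absence of any comparison leaves the outcome wide open. Compound 3 is expected to give 82% in this assay, with a range from 55% to 100%, which corresponds to an expected step of a number 5 percentage points lower from compound 1 to compound 3 (within the scatter).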

Compound 3, a percentage reported as activity, at one concentration (the size of the read-out at that concentration, not a potency): 86%
Compound 3: the middle estimate sits 4 percentage points below what was measured; low and high end bracket the measured number.
By their numbers in this assay, from the lowest: compounds 3, 1 and 2 (each within the scatter of the next).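

Among these compounds, the step of a number 1 percentage points lower from compound 1 to compound 3 (within the scatter) is the first reading at the carbonyl carbon whose other neighbour is the double-bonded chain carbon, a part of the molecule the earlier pair left untouched. In this assay the two groups cannot be told apart, even though the 3,4-difluorophenyl carries no hydrogen-bond donor or acceptor, whereas the 4-aminophenyl carries one of each, and its two fluorines replace the single nitrogen. Compound 3 thus joins compound 1 and compound 2 in describing a weak effect at the concentration tested, and no measurement on hand bears on why these two groups read alike.

One exchange at this position cannot show whether the carbonyl carbon tolerates change in general, since a plain phenyl, a 4-carboxyphenyl or a small alkyl chain in place of the ring could still read differently. It also remains open whether the hydrogen in place of methoxy on the other aromatic ring would read the same alongside the 3,4-difluorophenyl, and whether any of these compounds would separate at a higher concentration.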